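Adding a methoxy group to compound 1

The compounds below may be only part of what the source reports. "The series", "measured", "known", "first", "only" and "open" are said of these compounds alone.

In a functional assay on SW480 cells (Homo sapiens) for antiproliferative activity, read by sulforhodamine B assay, with a stated time of 48 h (a lower number here means a stronger inhibitor, a higher number a weaker inhibitor), compound 1 (`COc1ccc(C(=O)/C=C/c2ccccc2-c2ccc(F)cc2)cc1OC`) gives 8300 nM. Compound 2 (`COc1cc(C(=O)/C=C/c2ccccc2-c2ccc(F)cc2)ccc1O`) gives 4200 nM, and a 2.0-fold lower number from compound 1 to compound 2 (0.30 log units; within the scatter) stays within the scatter. Compound 3 (`COc1ccc(C(=O)/C=C/c2ccccc2-c2ccc(F)cc2)cc1O`) gives 340 nM, and a 24-fold lower number from compound 1 to compound 3 (1.39 log units; beyond the scatter) is large. Compound 1 therefore sits level with compound 2 and clearly above compound 3. Compound 4 (`COc1cc(C(=O)/C=C/c2ccccc2-c2ccc(F)cc2)cc(OC)c1OC`) differs from compound 1 in another way: methoxy in place of hydrogen on an aromatic carbon. Both measured steps swap a methyl on an oxygen for hydrogen, so neither tests this change directly, and only a change within the scatter is expected in this assay. The expected step is a 1.7-fold lower number from compound 1 to compound 4 (0.22 log units; within the scatter). For compound 4, the estimated value is 5000 nM, within a range of 1200 nM to 20000 nM.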

Compound 4, half-maximal inhibitory concentration: 2200 nM
For compound 4 the middle estimate is 2.3-fold (0.36 log units) above the measured one, and the stated range covers the measured number.
By their numbers in this assay, from the lowest: compound 3; then compounds 4, 2 and 1 (each within the scatter of the next, the first and the last beyond it).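

In this assay, a 3.8-fold lower number from compound 1 to compound 4 (0.58 log units; beyond the scatter), so this aromatic carbon, ortho to a methoxy group and meta to a large group, takes a further methoxy with a modest gain in potency. Among these compounds, the earlier steps only replaced a methyl on an oxygen with hydrogen, so this is the first step here that adds a group to a ring carbon. Nothing available here explains the gain. Going by these compounds, whether the gain is specific to methoxy remains open: an amine, a chlorine atom or a longer ethoxy chain on this carbon could give a different number.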